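The source may hold more compounds than are shown below. What is called first, only, known or untested is meant among the compounds shown, and "the series" means these compounds.

Four compounds built on one shared core were examined in an ADME assay on LLC-MK2 cells (Macaca mulatta) for cytotoxicity, read by spectrophotometry and crystal violet staining, with a stated time of 4 days; on this read-out higher numbers stand for lower toxicity in this test and lower numbers for higher toxicity in this test. Compound 1 `CC(C)n1ncc2c(C(=O)Nc3ccccc3F)cc(-c3ccccn3)nc21` gives 100000 nM. Compound 2 `CC(C)n1ncc2c(C(=O)Nc3ccncc3)cc(-c3cccs3)nc21` gives 6300 nM, which is the lowest of the two numbers recorded; compound 1 sits clearly higher, and that gap lies beyond the scatter. Compound 3 `CC(C)n1ncc2c(C(=O)Nc3ccccc3F)cc(-c3ccccc3)nc21` yields only a limit of the assay rather than a number, > 200000 nM.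

The step to be judged runs from compound 2 to compound 4 `CC(C)n1ncc2c(C(=O)Nc3ccccn3)cc(-c3cccs3)nc21`, and the change is pyridin-2-yl in place of pyridin-4-yl on an amide-type nitrogen. Among the compounds with values here, only one measured step is available, an at least 2.0-fold higher number from compound 1 to compound 3 (0.30 log units; that floor lies within the scatter), and it concerns another group at another place, on an aromatic carbon rather than on the amide-type nitrogen, so it does not bear directly on the present change; its floor, moreover, lies within the scatter. Within the data shown here, no measured pair exchanges pyridin-4-yl for pyridin-2-yl on the amide-type nitrogen, and nothing recorded here points toward a shift in either direction.

The expected step is therefore no change at the digits printed from compound 2 to compound 4 (within the scatter), which stays within the scatter. For compound 4 the estimated value in this assay is 6300 nM, with a range from 2500 nM to 16000 nM.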

Compound 4, half-maximal cytotoxic concentration: > 200000 nM
Compound 4: a limit, no number; the forecaster's own chance of this, stated with the estimate: 5%; middle value at least 31-fold (1.50 log units) from the limit.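

In this assay, exchanging pyridin-4-yl for pyridin-2-yl on the amide-type nitrogen, with the rest of the molecule unchanged, gives an at least 31-fold higher number from compound 2 to compound 4 (1.50 log units; beyond the scatter). Within the data shown here, this is the first measured change at this place, and it shows that two groups with the same atoms, joined differently, are not interchangeable here: in this test, compound 4 is clearly less toxic than compound 2. The full size of the step stays unknown, since the reading for compound 4 is a limit of the assay and not a number: the limit of > 200000 nM in this assay, at which 2 of the 4 values shown sit.

The compounds shown leave open what pyridin-3-yl or a ring carrying an amine would give on the same amide-type nitrogen, and so whether pyridin-4-yl alone stands out or pyridin-2-yl does. They also leave open whether the same exchange has a similar effect when phenyl, as in compound 3, or pyridin-2-yl, as in compound 1, sits on the aromatic carbon of the shared core, as this one pair cannot establish a general pattern.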